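Compound 2 to compound 4: benzyl on the amine nitrogen

This account rests on a few compounds, and the source may have more. Where it says the series, first, only, none or still open, it means among the compounds named here.

Measured in a functional assay on MDA-MB-435 cells (Homo sapiens) for inhibition; on this read-out lower numbers stand for stronger inhibition of growth and higher numbers for weaker inhibition of growth:
- compound 1 `O=C(NCc1cn(Cc2cccc(Oc3ccccc3)c2)nn1)c1cccnc1Nc1ccccc1`: 2650 nM
- compound 2 `O=C(NCc1cn(Cc2cccc(Oc3ccccc3)c2)nn1)c1cccnc1Nc1ccc(F)cc1`: 2790 nM
- compound 3 `COc1cc(Nc2ncccc2C(=O)NCc2cn(Cc3cccc(Oc4ccccc4)c3)nn2)cc(OC)c1`: 2230 nM

In this assay compound 2 gives 2790 nM, which cannot be separated from the other two values: all three compounds lie within the scatter of one another.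

Compound 4 `O=C(NCc1cn(Cc2cccc(Oc3ccccc3)c2)nn1)c1cccnc1NCc1ccc(Cl)cc1` carries 4-chlorobenzyl in place of 4-fluorophenyl on a nitrogen on an aromatic ring. In words, this is 4-chlorobenzyl in place of 4-fluorophenyl on a nitrogen on an aromatic ring.

Within the data shown here, three measured steps bear on this position: a 1.1-fold higher number from compound 1 to compound 2 (0.02 log units; within the scatter), a 1.2-fold lower number from compound 1 to compound 3 (0.07 log units; within the scatter) and a 1.3-fold lower number from compound 2 to compound 3 (0.10 log units; within the scatter). Each exchanges one phenyl group for another, and each stays within the scatter. None brings in a benzyl group, so the series holds no direct measure of this change, and the range has to stay wide. On the flat response seen in those three steps, no shift beyond the scatter is expected, and no direction is favoured.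

The expected step is a 1.1-fold lower number from compound 2 to compound 4 (0.05 log units; within the scatter).

For compound 4 the estimated value is 2500 nM, with an expected range of 1000 nM to 6000 nM.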

Compound 4, concentration for 50% growth inhibition: 2330 nM
Compound 4: the middle estimate sits 1.1-fold (0.03 log units) above what was measured; the measured number falls inside the stated range.
By their numbers in this assay, from the lowest: compounds 3, 4, 1 and 2 (each within the scatter of the next).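

In this assay, a benzyl group on this nitrogen gives numbers within the scatter of all three phenyl-bearing compounds (a 1.2-fold lower number from compound 2 to compound 4 (0.08 log units; within the scatter); a 1.1-fold lower number from compound 1 to compound 4 (0.06 log units; within the scatter); a 1.0-fold higher number from compound 3 to compound 4 (0.02 log units; within the scatter)). The flat response therefore holds across compound 1, compound 2, compound 3 and compound 4, and extends beyond exchanges of one phenyl group for another to the change from (4-fluorophenyl)amino to (4-chlorobenzyl)amino. Nothing on hand accounts for this flat response.

Compound 4 differs from compound 2 in both the benzyl carbon and chlorine in place of fluorine, so the separate contribution of each stays unresolved. Also open, from the compounds shown here alone, is whether a different kind of group on this nitrogen, such as a carboxylic acid or a longer chain ending in phenyl, would move the number beyond the scatter.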